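A few compounds are considered here, and "the series" means these few. Any claim that something is new, unique, unknown or untested is made for them only; others in the source may bear on it.

In a toxicity assay on CCRF-CEM cells (Homo sapiens) for cytotoxicity (a lower number here means that less compound is tolerated, a higher number that more compound is tolerated), compound 3 `[N-]=[N+]=NCc1cccc2c1nc(-c1c(F)cccc1F)n2Cc1c(F)cccc1F` stands at > 100 uM, which is a limit and not a number. Compound 4 `CC(=O)N(C)Cc1cccc2c1nc(-c1c(F)cccc1F)n2Cc1c(F)cccc1F` differs from it in one place: acetyl(methyl)amino in place of azido on a saturated chain carbon bound to an aromatic carbon. Two relatives carry other groups in this place: compound 1 `CN(C)C(=O)c1cccc2c1nc(-c1c(F)cccc1F)n2Cc1c(F)cccc1F` gives 80.1 uM and compound 2 `CC(C)=CCc1cccc2c1nc(-c1c(F)cccc1F)n2Cc1c(F)cccc1F` gives 28.3 uM. Swapping this group has so far produced a 2.8-fold lower number from compound 1 to compound 2 (0.45 log units; beyond the scatter), an at least 3.5-fold higher number from compound 2 to compound 3 (0.54 log units; beyond the scatter) and an at least 1.2-fold higher number from compound 1 to compound 3 (0.09 log units; that floor lies within the scatter). Compound 4 shares a carbonyl with the dimethylcarbamoyl of compound 1, so a modest fall or none beyond the scatter is expected in this assay. The expected change is an at least 1.3-fold lower number from compound 3 to compound 4 (0.12 log units; that floor lies within the scatter). For compound 4 the estimate is 75 uM, with an expected range of 35 uM to 130 uM.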

Compound 4, half-maximal toxic concentration: 20.6 uM
The estimate for compound 4 lay 3.6-fold (0.56 log units) above the measured number; the measured number lies below the stated range.
By their numbers in this assay, from the lowest: compounds 4 and 2 (each within the scatter of the next); then compound 1. At a limit, above all of these: compound 3.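

In this assay, this saturated chain carbon bound to an aromatic carbon can carry a carbonyl group and still give a clear fall: acetyl(methyl)amino in place of azido gives an at least 4.8-fold lower number from compound 3 to compound 4 (0.68 log units; beyond the scatter). A shared carbonyl does not match the dimethylcarbamoyl group, with a 3.9-fold lower number from compound 1 to compound 4 (0.59 log units; beyond the scatter), while the 2-methylprop-1-en-1-yl group is no different in effect, with a 1.4-fold lower number from compound 2 to compound 4 (0.14 log units; within the scatter). The first step gives only a floor, as compound 3 stands at a limit and not a number: the limit of > 100 uM in this assay, at which 1 of the 4 values shown sits.

Still open, on these data alone, is whether a simple amine or a carboxylic acid on this chain carbon would stay with azido or fall with acetyl(methyl)amino.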